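Replacing the Pyridine Amide with a Thiadiazole Amide

This account rests on a few compounds, and the source may have more. Where it says the series, first, only, none or still open, it means among the compounds named here.

Compound 1, `CCCCNc1nc(N)nc2c1CNCC2`, gives 7.2 uM in an assay on HEK293 cells for agonist activity at Toll-like receptor 8 (Homo sapiens), read by a luciferase reporter, with a stated time of 6 h; on this read-out lower numbers stand for an effect already at smaller amounts and higher numbers for an effect only at larger amounts of compound.
Compound 2, `CCCCNc1nc(N)nc2c1CN(C(=O)CC)CC2`, gives 0.4 uM.
Compound 3, `CCCCNc1nc(N)nc2c1CN(C(=O)c1ccccn1)CC2`, gives 2.9 uM.

Compound 3 stands second highest of the three numbers in this assay. It sits nearer to compound 1, as a 2.5-fold lower number from compound 1 to compound 3 (0.39 log units; beyond the scatter) shows, and further from compound 2, as a 7.3-fold higher number from compound 2 to compound 3 (0.86 log units; beyond the scatter) shows. Compound 4, `CCCCNc1nc(N)nc2c1CN(C(=O)c1csnn1)CC2`, differs from compound 3 in one place: 1,2,3-thiadiazol-4-yl in place of pyridin-2-yl on a carbonyl carbon.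

Of the measured steps, only a 7.3-fold higher number from compound 2 to compound 3 (0.86 log units; beyond the scatter) alters the group on the carbonyl carbon, and that step was modest. The other two, an 18-fold lower number from compound 1 to compound 2 (1.26 log units; beyond the scatter) and a 2.5-fold lower number from compound 1 to compound 3 (0.39 log units; beyond the scatter), add an acyl group to a bare ring nitrogen rather than exchanging one acyl group for another, so they bear on the change only loosely. Within the data shown here, no measured pair exchanges one aromatic ring for another on the carbonyl carbon, so the direction of the step is not settled by these data. The expected step for this change is a 1.5-fold lower number from compound 3 to compound 4 (0.16 log units; within the scatter), a small step possibly toward a lower number and not clearly beyond the scatter. For compound 4 the expected value in this assay is 2 uM, with a range from 0.5 uM to 8 uM.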

Compound 4, minimum effective concentration: 0.1 uM
The estimate for compound 4 lay 20-fold (1.30 log units) above the measured number; the whole stated range lies above it.
By their numbers in this assay, from the lowest: compound 4; then compound 2; then compound 3; then compound 1.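

Among the earlier compounds, the only aromatic ring on this carbonyl carbon came with a higher number than ethyl in this assay (a 7.3-fold higher number from compound 2 to compound 3 (0.86 log units; beyond the scatter)), but 1,2,3-thiadiazol-4-yl goes the other way (a 4.0-fold lower number from compound 2 to compound 4 (0.60 log units; beyond the scatter)). An aromatic ring at this place is therefore not tied to one direction, and the choice of ring can matter a great deal, as the exchange for pyridin-2-yl shows (a 29-fold lower number from compound 3 to compound 4 (1.46 log units; beyond the scatter)). Acylating the ring nitrogen can also achieve more than the earlier compounds revealed (a 72-fold lower number from compound 1 to compound 4 (1.86 log units; beyond the scatter)), yet nothing available here explains why this ring gives so much lower a number than pyridin-2-yl.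

The change replaces a six-membered aromatic ring with 1 hetero atom by a five-membered one with 3 hetero atoms, and these compounds cannot separate the effect of ring size from that of the hetero atoms. From the compounds shown here alone, it also remains open whether a plain phenyl ring, a thiophene ring or a longer chain such as butanoyl on the same carbonyl carbon would fall nearer to compound 4 or to compound 3.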